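The source may report more compounds than this note shows. Statements on the series, on what has been measured and on what is new or still open speak of the compounds shown alone.

Compound 2 `COC(=O)C1(c2ccccc2)CC1CN1CCN(c2ncccn2)CC1` gives 3090 nM in an assay for displacement of a labelled ligand from Sigma non-opioid intracellular receptor 1 (Cavia porcellus) (a higher number here means a weaker inhibitor, a lower number a stronger inhibitor), the highest of the three numbers: compound 1 `COC(=O)C1(c2ccccc2)CC1CN1CCN(c2ccccn2)CC1` gives 1330 nM, and compound 3 `COC(=O)C1(c2ccc([N+](=O)[O-])cc2)CC1CN1CCC(Cc2ccccc2)CC1` gives 0.68 nM. For the measured compounds named here, the only measured single-point step, a 2.3-fold higher number from compound 1 to compound 2 (0.37 log units; beyond the scatter), concerns the group on the amine nitrogen. Compound 4 `COC(=O)C1(c2ccc(C)cc2)CC1CN1CCN(c2ncccn2)CC1` differs from compound 2 by methyl in place of hydrogen on an aromatic carbon. Going by the values given here, no measured step changes the phenyl ring alone; compound 3, which also carries a group on that ring, differs from compound 2 in several places at once, so its far lower number cannot be attributed to the ring. Compound 4 is therefore expected to sit close to its parent, the expected step being a 1.4-fold lower number from compound 2 to compound 4 (0.15 log units; within the scatter), within the scatter. The estimate for compound 4 is 2200 nM, with a range from 700 nM to 7000 nM.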

Compound 4, inhibition constant: 353 nM
Compound 4: the middle estimate sits 6.2-fold (0.79 log units) above what was measured, and the stated range ends above it.
By their numbers in this assay, from the lowest: compound 3; then compound 4; then compound 1; then compound 2.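

In this assay, phenyl to 4-methylphenyl gives an 8.8-fold lower number from compound 2 to compound 4 (0.94 log units; beyond the scatter). For the compounds shown here, this is the first step that changes the phenyl ring alone, and it shows that a single methyl at this place, para to a large group, moves the number beyond the scatter. Nothing available explains this step.

Going by these compounds, whether the methyl has the same effect with the pyridin-2-yl group of compound 1 remains open. So does what an ethyl group, a methoxy group or a chlorine atom would do at this place.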